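The compounds below may be only part of what the source reports. "The series", "measured", "known", "first", "only" and "open" are said of these compounds alone.

Measured compounds:
compound 1 `Cn1cncc1CN1CC(N(CC2CCN(S(C)(=O)=O)CC2)S(=O)(=O)c2ccccn2)Cc2cc(C#N)ccc21`: 0.1 10^-6 cm/s
compound 2 `Cn1cnc(S(=O)(=O)N(Cc2cccc(-n3cccc3)c2)C2Cc3cc(C#N)ccc3N(Cc3cncn3C)C2)c1`: 0.2 10^-6 cm/s
compound 3 `Cn1cncc1CN1CC(N(CCn2cccc2)S(=O)(=O)c2ccccn2)Cc2cc(C#N)ccc21`: 12.4 10^-6 cm/s

Among the measured compounds shown here, in an ADME assay on Caco-2 cells (Homo sapiens) for permeability, in the apical to basolateral direction (on this read-out higher numbers stand for higher permeability and lower numbers for lower permeability), compound 1 gives 0.1 10^-6 cm/s, the smallest of the three numbers, though compound 2 at 0.2 10^-6 cm/s sits within the scatter of it; compound 3 at 12.4 10^-6 cm/s is the far end, and a 120-fold higher number from compound 1 to compound 3 (2.09 log units; beyond the scatter) is the one single-place step in this assay. Compound 4 `Cn1cncc1CN1CC(N(CC2CCN(C(=O)OCc3ccccc3)CC2)S(=O)(=O)c2ccccn2)Cc2cc(C#N)ccc21` keeps the whole of compound 1 except for one change: benzyloxycarbonyl in place of methylsulfonyl on an amine nitrogen in a ring.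

For the measured compounds named here, the step from compound 1 to compound 3 removes the entire 1-(methylsulfonyl)piperidin-4-yl group, so it shows only that this region of compound 1 can move this assay strongly; no measured pair swaps one group for another on the amine nitrogen in the ring, and compound 2 alters a different position. An upward step of moderate size is therefore expected, a 10-fold higher number from compound 1 to compound 4 (1.00 log units; beyond the scatter), smaller than the measured one and uncertain in size. Compound 4 is estimated at 1 10^-6 cm/s, with a range from 0.2 10^-6 cm/s to 5 10^-6 cm/s.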

Compound 4, apparent permeability: 1 10^-6 cm/s
Compound 4: the middle estimate sits on the measured number at the digits printed; the range from low to high includes it.
By their numbers in this assay, from the lowest: compounds 1 and 2 (each within the scatter of the next); then compound 4; then compound 3.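

In this assay, a 10-fold higher number from compound 1 to compound 4 (1.00 log units; beyond the scatter) shows that the number can move beyond the scatter while the six-membered non-aromatic ring with 1 nitrogen stays in place, which a 120-fold higher number from compound 1 to compound 3 (2.09 log units; beyond the scatter) could not show because it removes that ring altogether. Benzyloxycarbonyl brings more heavy atoms and an aromatic ring of carbon only, while the counts of hydrogen-bond donors and acceptors stay the same as in methylsulfonyl. Nothing available assigns a cause to this step.

This single pair cannot separate the aromatic ring from the exchange of the sulfonyl for a carbamate. As far as these compounds go, a methyl carbamate, an acetyl group, a benzyl group or the free amine on that nitrogen would each bear on that question, and whether the step holds on other cores remains open.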